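Isopropyl Introduction on the Glycine Carbon of Compound 1

The compounds below may be only part of what the source reports. "The series", "measured", "known", "first", "only" and "open" are said of these compounds alone.

Measured so far:
- compound 1 `O=C(CN(c1ncnc2c1ncn2C1CCCCO1)C1CC1)NCC(=O)OCc1ccccc1`, giving 55.7% in a functional assay on the whole organism (Tail, strain ICR) with Mus musculus as the target, in the tail flick test, with a stated time of 30 min, at a dose of 25 umol/kg by the oral route; on this read-out lower numbers stand for a weaker effect and higher numbers for a stronger effect at the one dose given
- compound 2 `CC(C)[C@H](NC(=O)CN(c1nc(Cl)nc2[nH]cnc12)C1CC1)C(=O)O`, giving 31.2% in this assay

Compound 1 stands highest of the two numbers in this assay; compound 2 lies below it by a gap beyond the usual scatter. Compound 3 `CC(C)[C@H](NC(=O)CN(c1ncnc2c1ncn2C1CCCCO1)C1CC1)C(=O)OCc1ccccc1` differs from compound 1 in one place: isopropyl in place of hydrogen on a saturated chain carbon bound to an amide-type nitrogen and a carbonyl carbon. Within the data shown here, no step between measured compounds covers this change, and compound 2 differs from compound 1 in more than one place, so it cannot guide the estimate. In this assay a step of a number 5.7 percentage points lower from compound 1 to compound 3 (within the scatter) is expected, small and of uncertain direction. Compound 3 is therefore estimated at 50%, within 28% to 72%.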

Compound 3, a percentage reported as activity, at one dose (the size of the read-out at that dose, not a potency): 21.8%
Compound 3: middle estimate off by 28.2 percentage points, on the high side; measured number outside the range, below it.
By their numbers in this assay, from the lowest: compounds 3 and 2 (each within the scatter of the next); then compound 1.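

In this assay, isopropyl in place of hydrogen on a saturated chain carbon bound to an amide-type nitrogen and a carbonyl carbon gives a number 33.9 percentage points lower from compound 1 to compound 3 (beyond the scatter). Among these compounds, this is the first single-place comparison, and it shows that this carbon does not tolerate every substitution in this read-out. Nothing measured here bears on the reason for this step.
Still open, from the compounds shown here alone, is whether methyl or a longer chain on this carbon would give a similar step. An amine at the same place also remains untested in the compounds shown.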